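This account rests on a few compounds, and the source may have more. Where it says the series, first, only, none or still open, it means among the compounds named here.

Of the compounds shown here, two have numbers so far. Compound 1 `C#CCSc1nc(Nc2ccccc2Cl)c(C#N)c(-c2ccccc2)n1` gives 12400 nM in a functional assay on B16-F10 cells (Mus musculus) for inhibition, read by MTT assay, with a stated time of 72 h; a higher number here means a weaker inhibitor, a lower number a stronger inhibitor. Compound 2 `N#Cc1c(Nc2cccc(C(F)(F)F)c2)nc(SCc2cn(Cc3ccccc3Cl)nn2)nc1-c1ccccc1` gives 3710 nM in this assay, the lower of the two numbers; its gap to compound 1 lies beyond the scatter, so compound 2 stands as the stronger inhibitor of the pair. Among the compounds with values here, the two differ in several places at once, so no single step between them can be read.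

Compound 3 `N#Cc1c(Nc2ccc(Cl)cc2)nc(SCc2cn(Cc3ccccc3Cl)nn2)nc1-c1ccccc1` has not yet been measured in this assay. It differs from compound 2 in one place: 4-chlorophenyl in place of 3-(trifluoromethyl)phenyl on a nitrogen on an aromatic ring. Within the data shown here, no measured pair isolates this change, so no direction is backed by data. The expectation for the step from compound 2 to compound 3 is therefore a change of a 1.3-fold higher number from compound 2 to compound 3 (0.11 log units; within the scatter), judged likely to stay within the scatter, with somewhat more room allowed on the weaker side than on the stronger. On that basis compound 3 is estimated at 4800 nM in this assay, within a range from 1500 nM to 15000 nM.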

Compound 3, half-maximal inhibitory concentration: 1590 nM
Beside the measured number, compound 3's estimate is 3.0-fold (0.48 log units) above it; the range from low to high includes it.
By their numbers in this assay, from the lowest: compound 3; then compound 2; then compound 1.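

Within the data shown here, the group on the nitrogen on the aromatic ring is the first place where a single change can be read: in this assay, 4-chlorophenyl in place of 3-(trifluoromethyl)phenyl gives a 2.3-fold lower number from compound 2 to compound 3 (0.37 log units; beyond the scatter). This modest step shows that, with the rest of compound 2 held constant, the number responds to the choice of aryl group at this position, and within this one pair the change leads towards the stronger inhibitor. No measurement shown gives a cause for the step, and a single pair cannot separate the change of substituent from the change in its place on the phenyl ring.

Still open, as far as these compounds go, is whether chlorine and trifluoromethyl would keep this order if each carried the other's place on the ring, and how an unsubstituted phenyl, a methoxy group or an amine on that ring would read against compound 3. Also open, from the compounds shown here alone, is whether the same step holds when the triazole-bearing side chain of the shared core is replaced by a different group, such as a shorter alkyl chain or a carboxylic acid.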